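The source may report more compounds than this note shows. Statements on the series, on what has been measured and on what is new or still open speak of the compounds shown alone.

Compound 3 `N#Cc1cccc(S(=O)(=O)Oc2ccc(-c3cncn3C3CCN(C(=O)c4ccc([N+](=O)[O-])cc4)CC3)cc2)c1` is one of three compounds that share a core and were tested in an assay on HEK293 cells for antagonist activity at P2X purinoceptor 7 (Homo sapiens), read by fluorescence, with a stated time of 2 h; on this read-out lower numbers stand for stronger inhibition and higher numbers for weaker inhibition. On that read-out compound 3 gives 45 nM, which is the second highest of the three numbers. Compound 1 `N#Cc1cccc(S(=O)(=O)Oc2ccc(-c3cncn3C3CCN(C(=O)c4ccc(Cl)c(C(F)(F)F)c4)CC3)cc2)c1` gives 73 nM, and the step of a 1.6-fold lower number from compound 1 to compound 3 (0.21 log units; within the scatter) shows that swapping the group on the carbonyl carbon made no difference beyond the scatter. Compound 2 `CN(C)c1ccc(C(=O)N2CCC(n3cncc3-c3ccc(OS(=O)(=O)c4cccc5cnccc45)cc3)CC2)cc1` gives 0.11 nM, far below the other two, but it differs from compound 3 in two places, so its value alone cannot be tied to one change.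

Compound 4 `CN(C)c1ccc(C(=O)N2CCC(n3cncc3-c3ccc(OS(=O)(=O)c4cccc(C#N)c4)cc3)CC2)cc1` differs from compound 3 by dimethylamino in place of nitro on an aromatic carbon. Among the compounds with values here, no measured step covers this exchange directly. Within the data shown here, the one step available, from compound 1 to compound 3, concerned the same aromatic carbon yet stayed within the scatter, while compound 2 carries the same dimethylamino group and sits much lower. For compound 4 the expected step is therefore a 4.5-fold lower number from compound 3 to compound 4 (0.65 log units; beyond the scatter), a move toward stronger inhibition of moderate size, with wide uncertainty. Compound 4 is thus estimated at 10 nM, within a range from 1 nM to 80 nM.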

Compound 4, half-maximal inhibitory concentration: 32 nM
Compound 4: the middle estimate sits 3.2-fold (0.51 log units) below what was measured; the measured number falls inside the stated range.
By their numbers in this assay, from the lowest: compound 2; then compounds 4, 3 and 1 (each within the scatter of the next, the first and the last beyond it).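

In this assay there is a 1.4-fold lower number from compound 3 to compound 4 (0.15 log units; within the scatter) for dimethylamino in place of nitro on this aromatic carbon para to a large group, while 4-(dimethylamino)phenyl in place of 4-chloro-3-(trifluoromethyl)phenyl gives a 2.3-fold lower number from compound 1 to compound 4 (0.36 log units; beyond the scatter) as a modest step, so exchanges at this end of the molecule have so far moved the number only a little. The dimethylamino group does not by itself bring the low number seen with isoquinolin-5-yl on the sulfonyl sulfur: there is a 290-fold higher number from compound 2 to compound 4 (2.46 log units; beyond the scatter) when 3-cyanophenyl takes that place, so the large gap goes with the sulfonyl substituent in this pair. No measurement is available that explains any of these steps.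

Still open, from the compounds shown here alone, is how a carboxylic acid or a morpholine would read on this aromatic carbon. Also open, going by these compounds, is whether isoquinolin-5-yl gives a similar step when nitro stands in place of dimethylamino.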